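Compound 1 to compound 3: replacing the 5-hydroxypentyl group

The source may hold more compounds than are shown below. What is called first, only, known or untested is meant among the compounds shown, and "the series" means these compounds.

Compound 1 `COc1cc(NC(C)CCCNC(=O)NNC(=O)NCCCCCO)c2ncccc2c1` gives 168000 nM 
Compound 2 `COc1ccc(C(=NNC(=O)NNC(=O)NCCCC(C)Nc2cc(OC)cc3cccnc23)c2ccc(OC)cc2)cc1` gives 11000 nM 

In a functional assay on MIA PaCa-2 cells (Homo sapiens) for inhibition, read by MTT assay, with a stated time of 4 days (a higher number here means a weaker inhibitor, a lower number a stronger inhibitor), compound 1 has the higher of the two numbers, and compound 2 lies lower by more than the scatter. Compound 3 `COc1cc(NC(C)CCCNC(=O)NNC(=O)Nc2ccc(Cl)c(C(F)(F)F)c2)c2ncccc2c1` is still unmeasured. The change 4-chloro-3-(trifluoromethyl)phenyl in place of 5-hydroxypentyl on an amide-type nitrogen places 4-chloro-3-(trifluoromethyl)phenyl in place of 5-hydroxypentyl on an amide-type nitrogen. Within the data shown here, no measured pair differs in one place, so the evidence is thin. Among the measured compounds shown here, compound 2 also lacks the 5-hydroxypentyl group and gives 11000 nM in this assay as the only guide. A large move towards a stronger inhibitor, beyond the scatter, is therefore expected. The expected change is a 28-fold lower number from compound 1 to compound 3 (1.45 log units; beyond the scatter) on this reasoning. The estimate for compound 3 is 6000 nM and the expected range runs from 1500 nM to 25000 nM in this measurement.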

Compound 3, half-maximal inhibitory concentration: 18000 nM
Compound 3: middle estimate off by 3.0-fold (0.48 log units), on the low side, within the range that was stated.
By their numbers in this assay, from the lowest: compounds 2 and 3 (each within the scatter of the next); then compound 1.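

In this assay, among these compounds, 4-chloro-3-(trifluoromethyl)phenyl in place of 5-hydroxypentyl on an amide-type nitrogen gives a 9.3-fold lower number from compound 1 to compound 3 (0.97 log units; beyond the scatter) and is the first single-place step. This position therefore responds to its substituent, and the hydroxyl-bearing chain is not required there: a six-membered aromatic ring of carbon only, with 0 hydrogen-bond donors and 0 hydrogen-bond acceptors, gives the lower number. No measurement on hand accounts for the size of this step.

This single step changes the chain, the hydroxyl, the ring and both ring substituents together, so their contributions remain unseparated. Open comparisons include plain phenyl, 4-chlorophenyl and 3-(trifluoromethyl)phenyl on the same nitrogen, along with an unsubstituted pentyl chain and a pentyl chain ending in an amine or a carboxylic acid.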